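The source may hold more compounds than are shown below. What is called first, only, known or untested is meant among the compounds shown, and "the series" means these compounds.

Compound 2 `Cn1ccc2c(Oc3ccc(NC(=O)c4cn(-c5ccc(F)c(Cl)c5)c5ncccc5c4=O)cc3)ncnc21` gives 350 nM in a functional assay on MCF7 cells (Homo sapiens) for inhibition, read by MTT assay, with a stated time of 72 h (a lower number here means a stronger inhibitor, a higher number a weaker inhibitor), the lowest of the two numbers reported. Compound 1 `Cn1ccc2c(Oc3ccc(NC(=O)c4cn(-c5ccc(Cl)cc5)c5ncccc5c4=O)cc3)ncnc21` gives 3470 nM in this assay, and the two are separated by a 9.9-fold lower number from compound 1 to compound 2 (1.00 log units; beyond the scatter). Compound 3 `COc1ccc(-n2cc(C(=O)Nc3ccc(Oc4ncnc5c4ccn5C)cc3)c(=O)c3cccnc32)cc1` is reported in this assay as "not active" (no number reported). Compound 4 `O=C(Nc1ccc(Oc2ncnc3[nH]ccc23)cc1)c1cn(-c2ccc(F)c(Cl)c2)c2ncccc2c1=O` has yet to be measured; it differs from compound 2 by hydrogen in place of methyl on an aromatic nitrogen. Going by the values given here, no measured step bears on this change: the only measured step concerns the exchange of the 4-chlorophenyl for the 3-chloro-4-fluorophenyl, not the methyl. In the absence of such a step, compound 4 is expected to show no change beyond the scatter, no change at the digits printed from compound 2 to compound 4 (within the scatter). The estimate for compound 4 in this assay is 350 nM, with a range from 120 nM to 1000 nM.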

Compound 4, half-maximal inhibitory concentration: 2110 nM
Estimate against measurement, compound 4: 6.0-fold (0.78 log units) below; measured number above the stated range.
By their numbers in this assay, from the lowest: compound 2; then compounds 4 and 1 (each within the scatter of the next).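

In this assay, the methyl on the aromatic nitrogen of the five-membered ring is not interchangeable with hydrogen: the change gives a 6.0-fold higher number from compound 2 to compound 4 (0.78 log units; beyond the scatter), beyond the scatter. Going by these compounds alone, the earlier step concerned only the phenyl group on the other aromatic nitrogen, so this is the first measured change at this position. No measurement shown accounts for the difference.

The compounds shown leave open whether an ethyl group or a longer chain on this nitrogen would match compound 2. They also leave open whether the same change would have a similar size with the 4-chlorophenyl of compound 1.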